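Swapping the Terminal Amine on the Ether Chain

This account rests on a few compounds, and the source may have more. Where it says the series, first, only, none or still open, it means among the compounds named here.

Compound 3 `CCN1CCN(CCCOc2cc3nccc(Oc4c(F)cc(NC(=O)NN5C(=O)CSC5c5c(F)cccc5F)cc4F)c3cc2OC)CC1` carries the lowest number of the three measured compounds in a functional assay on A549 cells (Homo sapiens) for antiproliferative activity, read by MTT assay, with a stated time of 72 h (on this read-out lower numbers stand for stronger inhibition and higher numbers for weaker inhibition), giving 350 nM. Compound 1 `COc1cc2c(Oc3c(F)cc(NC(=O)NN4C(=O)CSC4c4c(F)cccc4F)cc3F)ccnc2cc1OCCCN1CCCC1` gives 560 nM, and the step of a 1.6-fold lower number from compound 1 to compound 3 (0.20 log units; within the scatter) lies within the scatter. Going by the values given here, compound 2 `COc1cc2c(Oc3c(F)cc(NC(=O)NN4C(=O)C(C)(C)SC4c4c(F)cccc4F)cc3F)ccnc2cc1OCCCN1CCCC1` gives 1450 nM; its number and that of compound 3 stand apart by more than the scatter, though no single-change step between compound 2 and compound 3 is given, so only the two values themselves can be compared.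

Compound 4 `COc1cc2c(Oc3c(F)cc(NC(=O)NN4C(=O)CSC4c4c(F)cccc4F)cc3F)ccnc2cc1OCCCN1CCc2sccc2C1` differs from compound 3 in a group of 9 heavy atoms (7 carbon, 1 nitrogen, 1 sulfur; one five-membered aromatic ring with 1 hetero atom, one six-membered non-aromatic ring with 1 hetero atom) in place of a group of 8 heavy atoms (6 carbon, 2 nitrogen; one six-membered non-aromatic ring with 2 hetero atoms), on a saturated chain carbon, three bonds along the chain from an oxygen on an aromatic ring. Among the compounds with values here, the one measured step at this place, a 1.6-fold lower number from compound 1 to compound 3 (0.20 log units; within the scatter), was within the scatter, so the only exchange of the amine at the end of this chain seen so far moved the number little. Within the data shown here, the entering group has no measured precedent here. Compound 4 is therefore expected to sit close to compound 3 in this assay, with no step beyond the scatter, and the expected step is a 1.4-fold higher number from compound 3 to compound 4 (0.15 log units; within the scatter). The estimate for compound 4 in this assay is 500 nM, with a range from 150 nM to 1700 nM.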

Compound 4, half-maximal inhibitory concentration: > 20000 nM
Compound 4 was reported as a limit; the forecaster's own chance of this, stated with the estimate: 2%; middle value at least 40-fold (1.60 log units) from the limit.
By their numbers in this assay, from the lowest: compounds 3 and 1 (each within the scatter of the next); then compound 2. At a limit, above all of these: compound 4.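

The chain carbon three bonds along from an oxygen on an aromatic ring had seemed undemanding, since the exchange of pyrrolidin-1-yl for 4-ethylpiperazin-1-yl gave only a 1.6-fold lower number from compound 1 to compound 3 (0.20 log units; within the scatter), but compound 4 shows that this place does not accept every terminal group: the sulfur-containing group of 9 heavy atoms gives an at least 57-fold higher number from compound 3 to compound 4 (1.75 log units; beyond the scatter) and an at least 35-fold higher number from compound 1 to compound 4 (1.55 log units; beyond the scatter). Compound 4 stands as a limit in this assay, the only one among the compounds shown: the limit of > 20000 nM in this assay, at which 1 of the 4 values shown sits. The computed counts of hydrogen-bond donors and acceptors and the net charge are the same for the leaving 4-ethylpiperazin-1-yl and the entering group, so these counts do not tell compound 3 from compound 4.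

The compounds shown leave open which part of the entering group goes with the large step, and a piperidin-1-yl or morpholin-4-yl group at the same chain carbon, or the entering group on a longer chain, would help to separate its two rings from the rest. Also open, going by these compounds, is whether the same group would behave alike on the core of compound 2.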